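The source may hold more compounds than are shown below. What is called first, only, known or untested is meant among the compounds shown, and "the series" means these compounds.

Measured so far in an assay on CHO cells for antagonist activity at transient receptor potential cation channel subfamily V member 1 (Homo sapiens), read by FLIPR and calcium flux; on this read-out higher numbers stand for weaker inhibition and lower numbers for stronger inhibition:
compound 1 `CC(C(=O)NCc1ccc(C(F)(F)F)nc1Cl)c1ccc(NS(C)(=O)=O)c(F)c1` gives 0.2 nM
compound 2 `CC(C(=O)NCc1ccc(C(F)(F)F)nc1C1CCC(C)(C)CC1)c1ccc(NS(C)(=O)=O)c(F)c1` gives 0.4 nM
compound 3 `CC1C=C(c2nc(C(F)(F)F)ccc2CNC(=O)C(C)c2ccc(NS(C)(=O)=O)c(F)c2)CCC1` gives 0.2 nM

Compound 3 sits level with compound 1, and the remaining step is a 2.0-fold lower number from compound 2 to compound 3 (0.30 log units; within the scatter), so all three numbers lie within the scatter of one another. Compound 4 `CC(C(=O)NCc1ccc(C(F)(F)F)nc1C1=CCC(C)(C)CC1)c1ccc(NS(C)(=O)=O)c(F)c1` differs from compound 3 in one place: 4,4-dimethylcyclohex-1-en-1-yl in place of 3-methylcyclohex-1-en-1-yl on an aromatic carbon. The measured steps that bear on this change are a 2.0-fold higher number from compound 1 to compound 2 (0.30 log units; within the scatter), no change at the digits printed from compound 1 to compound 3 (within the scatter) and a 2.0-fold lower number from compound 2 to compound 3 (0.30 log units; within the scatter); each is within the scatter, so exchanging groups at this position has so far moved nothing beyond it. Compound 4 is therefore expected to show a step of a 1.5-fold higher number from compound 3 to compound 4 (0.18 log units; within the scatter), none beyond the scatter. For compound 4 the estimate is 0.3 nM, with a range from 0.1 nM to 0.9 nM.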

Compound 4, inhibition constant: 0.2 nM
Compound 4: the middle estimate sits 1.5-fold (0.18 log units) above what was measured, and the stated range covers the measured number.
By their numbers in this assay, from the lowest: compounds 1, 3, 4 and 2 (each within the scatter of the next).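

In this assay, for the compounds shown here, 4,4-dimethylcyclohex-1-en-1-yl in place of 3-methylcyclohex-1-en-1-yl stays within the scatter (no change at the digits printed from compound 3 to compound 4 (within the scatter)), so moving from one methyl on the ring to two at another ring carbon adds no visible step. The same holds with the ring double bond added (a 2.0-fold lower number from compound 2 to compound 4 (0.30 log units; within the scatter)) and for this group in place of chloro (no change at the digits printed from compound 1 to compound 4 (within the scatter)), so all four groups at this position remain within the scatter of one another. No supporting measurement is available to explain why these groups read alike.
Still open, on these data alone, is whether an amine or a carboxylic acid on this aromatic carbon would also stay within the scatter. A phenyl ring there is equally untested among the compounds shown.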